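Trifluoromethyl in Place of Hydroxy on a Shared Core

This account rests on a few compounds, and the source may have more. Where it says the series, first, only, none or still open, it means among the compounds named here.

Measured compounds:
compound 1 `O=C(/C=C/c1ccc2c(c1)B(O)OC2)c1ccc(I)cc1`, 14900 nM in a functional assay on MDA-MB-231 cells (Homo sapiens) for cytotoxicity, read by MTT assay, with a stated time of 48 h; on this read-out higher numbers stand for weaker inhibition and lower numbers for stronger inhibition
compound 2 `O=C(/C=C/c1ccc2c(c1)B(O)OC2)c1ccc(O)cc1`, 25600 nM in this assay

Among the compounds with values here, compound 2 gives the higher of the two numbers so far, but the step of a 1.7-fold higher number from compound 1 to compound 2 (0.24 log units; within the scatter) lies within the scatter, so the two compounds cannot be told apart on this read-out. The unmeasured compound 3 `O=C(/C=C/c1ccc2c(c1)B(O)OC2)c1ccc(C(F)(F)F)cc1` differs from compound 2 by trifluoromethyl in place of hydroxy on an aromatic carbon; in words, trifluoromethyl in place of hydroxy on an aromatic carbon of a six-membered aromatic ring of carbon only, para to a large group.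

Within the data shown here, the only measured step that bears on this position is a 1.7-fold higher number from compound 1 to compound 2 (0.24 log units; within the scatter), an exchange of iodo for hydroxy at the same aromatic carbon, and it stayed within the scatter. Nothing measured shows that a substituent at this carbon moves the number beyond the scatter, so compound 3 is expected to land close to compound 2, with at most a small shift toward the number of compound 1.

Compound 3 is therefore estimated at 18000 nM, in a range of 7000 nM to 45000 nM, a step of a 1.4-fold lower number from compound 2 to compound 3 (0.15 log units; within the scatter) that is expected to stay within the scatter.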

Compound 3, half-maximal inhibitory concentration: 9200 nM
The estimate for compound 3 lay 2.0-fold (0.29 log units) above the measured number; measured number inside the range.
By their numbers in this assay, from the lowest: compounds 3, 1 and 2 (each within the scatter of the next, the first and the last beyond it).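

In this assay, within the data shown here, a change at this aromatic carbon now gives a step beyond the scatter for the first time: trifluoromethyl in place of hydroxy gives a 2.8-fold lower number from compound 2 to compound 3 (0.44 log units; beyond the scatter), a modest step, whereas the earlier exchange of iodo for hydroxy gave a 1.7-fold higher number from compound 1 to compound 2 (0.24 log units; within the scatter). Trifluoromethyl in place of iodo gives a 1.6-fold lower number from compound 1 to compound 3 (0.21 log units; within the scatter), so these two groups cannot be told apart on this read-out, and the only separation among the three compounds is the one between the hydroxy and trifluoromethyl compounds, with the iodo compound within the scatter of both. Nothing available gives a reason for this separation, which therefore stands as an observation on these three compounds alone.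

The compounds shown leave open how an amine, a carboxylic acid, a nitrile or a longer chain at this same aromatic carbon would compare with hydroxy and trifluoromethyl on the shared core. They also leave open whether the step seen with trifluoromethyl would hold on another cell line, since all three numbers come from a single assay.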